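Phenol in place of the pentanoate on the shared core

The compounds below may be only part of what the source reports. "The series", "measured", "known", "first", "only" and "open" are said of these compounds alone.

Compound 3 `CCCCC(=O)Oc1ccc2oc(/C=C/[S+](C)[O-])cc(=O)c2c1` carries (butylcarbonyl)oxy on an aromatic carbon of the shared core. In a functional assay on A549 cells (Homo sapiens) for cytotoxicity, with a stated time of 48 h (a higher number here means a weaker inhibitor, a lower number a stronger inhibitor), compound 3 gives 2400 nM, the highest of the two numbers at hand, though its neighbour compound 2 `C[S+]([O-])/C=C/c1cc(=O)c2cc(F)ccc2o1` is within the scatter of it, giving 2100 nM in this assay; the gap reads a 1.1-fold higher number from compound 2 to compound 3 (0.06 log units; within the scatter), so the two cannot be ordered. Compound 1 `C[S+]([O-])/C=C/c1cc(=O)c2cc(C#N)ccc2o1` with cyano returns only a limit, > 10000 nM in this assay (the limit of > 10000 nM in this assay, at which 1 of the 3 values shown sits). Against that limit the steps of an at least 4.7-fold lower number from compound 1 to compound 2 (0.67 log units; beyond the scatter) and an at least 4.1-fold lower number from compound 1 to compound 3 (0.61 log units; beyond the scatter) show that fluoro and (butylcarbonyl)oxy both leave cyano behind.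

Compound 4 `C[S+]([O-])/C=C/c1cc(=O)c2cc(O)ccc2o1` differs from compound 3 as hydrogen in place of butylcarbonyl on an oxygen on an aromatic ring. For the measured compounds named here, none of the measured steps trades a group on that oxygen; the one exchange at the same aromatic carbon, fluoro for (butylcarbonyl)oxy, stayed within the scatter. So there is no basis for a direction, and the expected step in this assay is a 1.3-fold higher number from compound 3 to compound 4 (0.10 log units; within the scatter), within the scatter. Compound 4 is therefore estimated at 3000 nM in this assay, with a range of 1000 nM to 9000 nM, the upper end allowing that a limit may be reported.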

Compound 4, half-maximal inhibitory concentration: 10500 nM
Estimate against measurement, compound 4: 3.5-fold (0.54 log units) below; measured number above the stated range.
By their numbers in this assay, from the lowest: compounds 2 and 3 (each within the scatter of the next); then compound 4.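

In this assay hydrogen in place of butylcarbonyl on the oxygen gives a 4.4-fold higher number from compound 3 to compound 4 (0.64 log units; beyond the scatter) and hydroxy in place of fluoro gives a 5.0-fold higher number from compound 2 to compound 4 (0.70 log units; beyond the scatter) so this aromatic carbon does respond to the group it carries. The earlier exchange of fluoro for (butylcarbonyl)oxy gave no readable difference, and that flat result now proves to hold for those two groups only, with the free hydroxy of compound 4 standing clear of both compound 2 and compound 3. The step from compound 1 to compound 4 cannot be read, since compound 1 returns only a limit: the limit of > 10000 nM in this assay, at which 1 of the 4 values shown sits.

Whether a shorter acetate, a longer chain or a methyl ether on the same oxygen would read with compound 3 or with compound 4 stays open, so the shown data do not tell whether the pentanoate chain itself matters or only the capping of the oxygen. From the compounds shown here alone, how an amine or a carboxylic acid at this aromatic carbon would read also stays open.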